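A few compounds are considered here, and "the series" means these few. Any claim that something is new, unique, unknown or untested is made for them only; others in the source may bear on it.

Compound 1, drawn as `COc1ccc(Sc2ccccc2N2CC(C)N(CC(=O)O)CC2C)cc1`, stands lowest among the two numbers given in an assay for inhibition of sodium- and chloride-dependent glycine transporter 1 (Homo sapiens) (on this read-out higher numbers stand for weaker inhibition and lower numbers for stronger inhibition), where compound 1 gives 580 nM. Its nearest neighbour is compound 2, `COc1ccc(Sc2ccccc2N2C[C@@H](C)N(CC(=O)O)C[C@H]2C)cc1`, which in this assay gives 16000 nM; the step of a 28-fold higher number from compound 1 to compound 2 (1.44 log units; beyond the scatter) is measured across a pair whose only difference is that noted in the fact that one of compounds 1 and 2 is drawn with a defined configuration and the other without, at the place where they differ. Compound 3, `COc1ccc(Sc2ccccc2N2CCN(CC(=O)O)CC2C)cc1`, reaches only a limit of this assay, reported as > 10000 nM. That limit, described by the limit of > 10000 nM in this assay, at which 1 of the 3 values shown sits, bounds the step of an at least 17-fold higher number from compound 1 to compound 3 (1.23 log units; beyond the scatter).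

Compound 4, `CC1CN(c2ccccc2Sc2ccc(Cl)cc2)C(C)CN1CC(=O)O`, differs from compound 1 by chloro in place of methoxy on an aromatic carbon. Among the compounds with values here, both measured steps from compound 1 concern changes at the saturated ring carbons, and neither touches the aromatic ring where compound 4 is altered; no measured step therefore bears on this change. With nothing to point either way, the step of a 1.2-fold higher number from compound 1 to compound 4 (0.08 log units; within the scatter) in this assay is expected to stay within the usual scatter. Compound 4 is accordingly estimated at 700 nM, with a range from 200 nM to 2500 nM.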

Compound 4, half-maximal inhibitory concentration: 360 nM
Compound 4: middle estimate off by 1.9-fold (0.29 log units), on the high side; low and high end bracket the measured number.
By their numbers in this assay, from the lowest: compounds 4 and 1 (each within the scatter of the next); then compound 2.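

In this assay, chloro in place of methoxy on an aromatic carbon, para to a large group, gives a 1.6-fold lower number from compound 1 to compound 4 (0.21 log units; within the scatter), so this place tolerates the exchange of these two groups without a change beyond the scatter. The earlier steps, all large, lay at the saturated ring carbons, whereas this one, the only step shown at the aromatic ring, is small. Nothing in the data shown gives a reason for this outcome.

From the compounds shown here alone, it remains open whether other groups at this place, such as trifluoromethyl, an amine or a carboxylic acid, would also stay within the scatter of compound 1. Also open, going by these compounds, is how compound 4 would read with a defined configuration at its saturated ring carbons.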